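A few compounds are considered here, and "the series" means these few. Any claim that something is new, unique, unknown or untested is made for them only; others in the source may bear on it.

Working notes on the series, read in a functional assay on HL-60 cells (Homo sapiens) for cytotoxicity, read by CellTiter-Blue, with a stated time of 48 h; on this read-out higher numbers stand for weaker inhibition and lower numbers for stronger inhibition. Compound 1 `CCOC(=O)CC1C(C(=O)OCC)=C(N)Oc2ccc(-c3ccccc3F)cc21` gives 73000 nM. Compound 2 `CCOC(=O)CC1C(C(=O)OCC)=C(N)Oc2ccc(-c3cc(F)cc(F)c3)cc21` gives 35900 nM. Compound 3 `CCOC(=O)CC1C(C(=O)OCC)=C(N)Oc2ccc(-c3ccco3)cc21` reports > 80000 nM, which is a limit of the assay and not a number. Compound 3 therefore stands at the limit of > 80000 nM in this assay, at which 1 of the 3 values shown sits.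

The next change leads to compound 4 `CCOC(=O)CC1C(C(=O)OCC)=C(N)Oc2ccc(-c3ccncc3)cc21`, with pyridin-4-yl in place of furan-2-yl on an aromatic carbon. Three measured exchanges at this aromatic carbon bear on it: a 2.0-fold lower number from compound 1 to compound 2 (0.31 log units; beyond the scatter), an at least 1.0-fold higher number from compound 1 to compound 3 (0.03 log units; that floor lies within the scatter) and an at least 2.2-fold higher number from compound 2 to compound 3 (0.34 log units; beyond the scatter). None of the three is more than modest, so only a small shift is expected in this assay, toward a lower number if any, and it may not clear the scatter. The expected move is an at least 1.3-fold lower number from compound 3 to compound 4 (0.12 log units; that floor lies within the scatter). A reading at the limit of the assay would not be a surprise. For compound 4 the estimate is 60000 nM, with an expected range from 30000 nM to 100000 nM.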

Compound 4, half-maximal inhibitory concentration: 10200 nM
Estimate against measurement, compound 4: 5.9-fold (0.77 log units) above; measured number below the stated range.
By their numbers in this assay, from the lowest: compound 4; then compound 2; then compound 1. At a limit, above all of these: compound 3.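

In this assay, pyridin-4-yl gives the lowest number of the series at this aromatic carbon, with a 3.5-fold lower number from compound 2 to compound 4 (0.55 log units; beyond the scatter) and a 7.2-fold lower number from compound 1 to compound 4 (0.85 log units; beyond the scatter), so the two fluorinated phenyl groups are both surpassed by a ring that carries a nitrogen. Furan-2-yl also has one hetero atom, and it shares the same counts of hydrogen-bond donors and acceptors and the absence of net charge, yet the exchange gives an at least 7.8-fold lower number from compound 3 to compound 4 (0.89 log units; beyond the scatter), so those counts alone do not separate the two rings. That step has only a floor, as compound 3 is at a limit of the assay and not a number: the limit of > 80000 nM in this assay, at which 1 of the 4 values shown sits.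

Whether the ring nitrogen itself or the six-membered ring accounts for the shift stays open, and a plain phenyl or pyridin-3-yl would bear on that. Also open, on these data alone, is how an amine or a carboxylic acid on this ring would read in this assay.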